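The source may report more compounds than this note shows. Statements on the series, on what has been measured and on what is new or still open speak of the compounds shown alone.

Among the compounds with values here, in a functional assay on GBM3 cells (Homo sapiens) for antiproliferative activity, read by WST assay, with a stated time of 72 h (on this read-out higher numbers stand for weaker inhibition and lower numbers for stronger inhibition), compound 1 `O=C(Nc1cccc(Cl)c1)Nc1cc2ncncc2cc1OCc1ccccc1Cl` gives 2800 nM, the only actual number so far. Compound 2 `O=C(Nc1ccc(Cl)c(Cl)c1)Nc1cc2ncncc2cc1OCc1ccccc1F` reads > 10000 nM, which is a limit of the assay and not a number. Compound 3 `O=C(Nc1cc2ncncc2cc1OCc1ccccc1Cl)Nc1cccc2ccccc12` has naphthalen-1-yl in place of 3-chlorophenyl on an amide-type nitrogen. Within the data shown here, no measured pair tests this change, so in this assay the expected step is a 1.1-fold higher number from compound 1 to compound 3 (0.03 log units; within the scatter), with no shift beyond the scatter in either direction. The estimated value for compound 3 is 3000 nM, expected to fall between 1000 nM and 10000 nM.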

Compound 3, half-maximal inhibitory concentration: 2700 nM
Compound 3: the middle estimate sits 1.1-fold (0.05 log units) above what was measured; the range from low to high includes it.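

Placing naphthalen-1-yl in place of 3-chlorophenyl on an amide-type nitrogen gives a 1.0-fold lower number from compound 1 to compound 3 (0.02 log units; within the scatter) in this assay. This position therefore takes a second six-membered aromatic ring of carbon only, without the chlorine, with no shift beyond the scatter. Nothing measured here gives a reason for this result.

The compounds shown leave open whether this position also tolerates a non-aromatic group such as cyclohexyl or a longer alkyl chain. They also leave open how a phenyl ring carrying an amine or a carboxylic acid would read.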